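Aryl in Place of Methyl on a Seven-Membered Core

The compounds below may be only part of what the source reports. "The series", "measured", "known", "first", "only" and "open" are said of these compounds alone.

Compound 1 `C=CC(=O)N1C(=O)CC(C)Sc2ccccc21` is the smallest of three compounds measured in a functional assay on HL-60 cells (Homo sapiens) for cytotoxicity, read by CCK-8 assay, with a stated time of 24 h; a higher number here means a weaker inhibitor, a lower number a stronger inhibitor. In this assay compound 1 gives 199000 nM, the highest of the three numbers. Compound 2 `C=CC(=O)N1C(=O)CC(c2ccc(-c3ccccc3)cc2)Sc2ccccc21` gives 118000 nM in this assay, and compound 3 `C=CC(=O)N1C(=O)CC(c2ccc([N+](=O)[O-])cc2)Sc2ccccc21` gives 107000 nM. The gaps from compound 1 to either of the other two lie within the scatter, so the three stand together rather than in any order. Among the measured compounds shown here, the one step recorded between two of them, a 1.1-fold lower number from compound 2 to compound 3 (0.04 log units; within the scatter), is likewise within the scatter.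

Compound 4 `C=CC(=O)N1C(=O)CC(c2ccc(C#N)cc2)Sc2ccccc21` has not yet been measured in this assay. It differs from compound 1 in one place: 4-cyanophenyl in place of methyl on a saturated ring carbon. For the measured compounds named here, no measured step exchanges a methyl for an aryl group on the saturated ring carbon, but compound 2 and compound 3 both carry an aryl group on that carbon and both give numbers within the scatter of compound 1, while a 1.1-fold lower number from compound 2 to compound 3 (0.04 log units; within the scatter) shows that a nitro in place of phenyl on an aromatic carbon changes little. It is therefore expected that compound 4 sits with those two aryl compounds, with a step of a 1.7-fold lower number from compound 1 to compound 4 (0.24 log units; within the scatter) that stays within the scatter, and the estimate for compound 4 is 115000 nM, within a range from 60000 nM to 220000 nM.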

Compound 4, half-maximal inhibitory concentration: 115000 nM
The estimate for compound 4 equals the measured number at the digits printed; low and high end bracket the measured number.
By their numbers in this assay, from the lowest: compounds 3, 4, 2 and 1 (each within the scatter of the next).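

The exchange of methyl for 4-cyanophenyl on the saturated ring carbon next to the ring sulfur can now be read directly in this assay, and that step, a 1.7-fold lower number from compound 1 to compound 4 (0.24 log units; within the scatter), shows that this aryl group and the methyl cannot be told apart at this position. On the aromatic ring of that aryl group, the exchange of nitro for cyano gives a 1.1-fold higher number from compound 3 to compound 4 (0.03 log units; within the scatter), and the exchange of phenyl for cyano gives a 1.0-fold lower number from compound 2 to compound 4 (0.01 log units; within the scatter), so the three aryl compounds, which carry a nitro, a cyano or a phenyl group at the same place, stand together in this assay. Nothing beyond these numbers bears on why the methyl and the three aryl groups cannot be separated here.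

Going by these compounds, all four compounds keep the vinylcarbonyl group on the ring nitrogen, so it remains open whether a plain acetyl group there would stay within the scatter of compound 1. On these data alone, it also remains open whether an amine or a carboxylic acid on the aryl ring, or a longer chain in place of the methyl, would depart from these numbers.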